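Fluoro to iodo swap repeated on the longer-chain core

The source may report more compounds than this note shows. Statements on the series, on what has been measured and on what is new or still open speak of the compounds shown alone.

In a functional assay on HCT-116 cells (Homo sapiens) for inhibition, read by sulforhodamine B assay, with a stated time of 48 h, tested at 50 uM (a lower number here means less inhibition of growth, a higher number more inhibition of growth at the concentration tested), compound 2 `O=C1C(=O)N(CCCn2cc(COc3cc(=O)oc4ccccc34)nn2)c2ccc(F)cc21` gives 75%, compound 1 `O=C1C(=O)N(CCCn2cc(COc3cc(=O)oc4ccccc34)nn2)c2ccc(I)cc21` gives 65%, and compound 3 `O=C1C(=O)N(CCCCn2cc(COc3cc(=O)oc4ccccc34)nn2)c2ccc(F)cc21` gives 67%. The difference between the cores of compound 2 and compound 3 is not broken down here. Compound 4 `O=C1C(=O)N(CCCCn2cc(COc3cc(=O)oc4ccccc34)nn2)c2ccc(I)cc21` has not been measured.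

The change iodo in place of fluoro on an aromatic carbon made a number 10 percentage points lower from compound 2 to compound 1 (within the scatter). The same change, (iodo in place of fluoro on an aromatic carbon), is now made on the core of compound 3, and the two place descriptions agree word for word. The expectation for compound 4 rests on the earlier step of a number 10 percentage points lower from compound 2 to compound 1 (within the scatter). In this assay the corresponding step is expected to be of like size: a number 7 percentage points lower from compound 3 to compound 4 (within the scatter). For compound 4 the estimate in this assay is 60%, with a range from 45% to 75%.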

Compound 4, percent growth inhibition at one concentration: 57%
The estimate for compound 4 lay 3 percentage points above the measured number; the range from low to high includes it.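

In this assay, iodo in place of fluoro on the core of compound 3 gives a number 10 percentage points lower from compound 3 to compound 4 (within the scatter). Set beside the earlier step, the change carries over to the second core at matching size: the same change on two cores in this assay, a number 10 percentage points lower (within the scatter) from compound 2 to compound 1 and a number 10 percentage points lower (within the scatter) from compound 3 to compound 4, 0 percentage points apart, within the scatter of two such steps

Each step alone lies within the scatter, and the agreement rests on two pairs read at one concentration. It does not establish that iodo and fluoro differ in growth inhibition, nor that the match holds on further cores.

Open, as far as these compounds go, is how chloro, bromo or plain hydrogen at the same place would read. Also open, from the compounds shown here alone, is whether the step keeps its size with a longer chain than that of compound 3.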